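The source may report more compounds than this note shows. Statements on the series, on what has been measured and on what is new or still open speak of the compounds shown alone.

Measured so far in an assay on isolated protein for inhibition of Fatty-acid amide hydrolase 1 (Homo sapiens); a lower number here means a stronger inhibitor, a higher number a weaker inhibitor:
compound 1 `COc1cccc(CN2CCC(CCCC(=O)c3ncco3)CC2)c1` — 34 nM
compound 2 `O=C(CCCC1CCN(Cc2ccccc2Cl)CC1)c1ncco1` — 260 nM

For the measured compounds named here, compound 2 holds the higher of the two numbers recorded; the one measured step, a 7.6-fold higher number from compound 1 to compound 2 (0.88 log units; beyond the scatter), puts 2-chlorophenyl in place of 3-methoxyphenyl on the saturated chain carbon bound to the ring amine nitrogen, and compound 2 sits at its weaker end.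

Compound 3 `O=C(CCCC1CCN(Cc2ccccc2Br)CC1)c1ncco1` differs from compound 2 by bromo in place of chloro on an aromatic carbon, that is, 2-chlorobenzyl becomes 2-bromobenzyl. Going by the values given here, no measured step exchanges one such group for the other; the step from compound 1 to compound 2 changes the whole aryl group and pattern at once and so bears on this change only loosely. With nothing to point in either direction, the expected step from compound 2 is no change at the digits printed from compound 2 to compound 3 (within the scatter), within the usual scatter. Compound 3 is therefore estimated at 260 nM, with a range from 100 nM to 700 nM.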

Compound 3, half-maximal inhibitory concentration: 315 nM
Compound 3: the middle estimate sits 1.2-fold (0.08 log units) below what was measured; low and high end bracket the measured number.
By their numbers in this assay, from the lowest: compound 1; then compounds 2 and 3 (each within the scatter of the next).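

In this assay, bromo in place of chloro on an aromatic carbon, ortho to a large group, gives a 1.2-fold higher number from compound 2 to compound 3 (0.08 log units; within the scatter), so 2-chlorobenzyl and 2-bromobenzyl cannot be told apart at this place. Compound 1 also keeps a clear margin over this second halogen compound, with a 9.3-fold higher number from compound 1 to compound 3 (0.97 log units; beyond the scatter), which shows that the gap to the 3-methoxyphenyl compound holds for both the chloro and the bromo group. No supporting evidence bears on either step, and the result stands as a bare observation.

As far as these compounds go, what a 2-methoxyphenyl or a 3-bromophenyl group gives on the same core stays open, and with it whether the group itself or its place on the ring carries the gap to compound 1. Also open, from the compounds shown here alone, is whether a smaller fluoro or a nitrile at this place would match the two halogens.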